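The source may hold more compounds than are shown below. What is called first, only, known or untested is meant among the compounds shown, and "the series" means these compounds.

In a functional assay on MCF7 cells (Homo sapiens) for antiproliferative activity, read by sulforhodamine B assay, with a stated time of 48 h (on this read-out lower numbers stand for stronger inhibition and higher numbers for weaker inhibition), compound 1 `COc1cccc(/C=C/C(=O)/C=C(O)/C=C/c2cccc(OC)c2OC)c1OC` gives > 50000 nM, which is a limit of the assay and not a number. Among the compounds with values here, compound 2 `COc1ccc(C=C(C(=O)/C=C/c2cccc(OC)c2OC)C(=O)/C=C/c2cccc(OC)c2OC)cc1OC` gives 560 nM, so it holds the only true number available so far, and there is no second measured value to rank it against. Compound 3 `COc1cccc(C=C(C(=O)/C=C/c2cccc(OC)c2OC)C(=O)/C=C/c2cccc(OC)c2OC)c1OC` has not yet been measured. It has the same atoms as compound 2, joined differently: 2,3-dimethoxyphenyl in place of 3,4-dimethoxyphenyl on a double-bonded chain carbon bound to a double-bonded chain carbon. In words, this places 2,3-dimethoxyphenyl in place of 3,4-dimethoxyphenyl on a double-bonded chain carbon bound to a double-bonded chain carbon. Within the data shown here, no measured pair of compounds shows what such a swap does, so any forecast is anchored on compound 2 and its 560 nM, with a wide margin for uncertainty. The group that changes keeps the same size and the same counted features, so only a modest shift seems likely. The expected change, a 1.4-fold higher number from compound 2 to compound 3 (0.15 log units; within the scatter), is a slight weakening, not far beyond the usual scatter of repeated measurements. The estimated value for compound 3 is 800 nM, with an expected range from 250 nM to 3000 nM.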

Compound 3, half-maximal inhibitory concentration: 520 nM
For compound 3 the middle estimate is 1.5-fold (0.19 log units) above the measured one, and the stated range covers the measured number.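

Putting 2,3-dimethoxyphenyl in place of 3,4-dimethoxyphenyl on a double-bonded chain carbon bound to a double-bonded chain carbon gives a 1.1-fold lower number from compound 2 to compound 3 (0.03 log units; within the scatter) in this assay. Within the data shown here, this is the first step that can be read at this position, and it shows that the read-out does not separate these two arrangements of the same atoms, so compound 2 and compound 3 cannot be told apart here and the activity seen in compound 2 survives this particular swap. The data at hand offer no measurement that would explain this result.

Going by these compounds, what remains open is how far this insensitivity extends, since the two groups compared have the same size and the same counted features, and one swap of this kind cannot show what a truly different group would do at this position. A phenyl ring carrying an amine or a carboxylic acid, or one carrying a longer chain in place of the methoxy groups, could behave quite differently, and the compounds shown do not say whether the read-out would stay level or move.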